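A few compounds are considered here, and "the series" means these few. Any claim that something is new, unique, unknown or untested is made for them only; others in the source may bear on it.

Among the measured compounds shown here, in a functional assay on HepG2 cells (Homo sapiens) for inhibition, read by MTT assay, with a stated time of 48 h (on this read-out higher numbers stand for weaker inhibition of growth and lower numbers for stronger inhibition of growth), compound 1 (`COc1ccc(C(=O)N2N=C(c3ccccc3)CC2c2cn(C)c3ccccc23)cn1`) gives 3130 nM, the higher of the two numbers measured so far. For the measured compounds named here, the only other measured compound, compound 2 (`Cc1ccc(C(=O)N2N=C(c3ccccc3)CC2c2cn(C)c3ccccc23)cn1`), gives 1220 nM. Compound 3 (`COc1ccc2c(c1)c(C1CC(c3ccccc3)=NN1C(=O)c1ccc(OC)nc1)cn2C`) keeps the core of compound 1 and carries a single change: methoxy in place of hydrogen on an aromatic carbon. This places methoxy in place of hydrogen on an aromatic carbon of a six-membered aromatic ring of carbon only, part of a fused or bridged system of two rings. Going by the values given here, only one measured step is available as a guide, a 2.6-fold lower number from compound 1 to compound 2 (0.41 log units; beyond the scatter), and it is modest. That step replaces methoxy with methyl elsewhere in the structure, so it shows the size of a single-group change in this series but says nothing direct about the new place. Among the compounds with values here, no measured compound carries a group there, so the direction is open, and no step beyond the scatter is expected in this assay. The estimate means an expected 1.2-fold lower number from compound 1 to compound 3 (0.08 log units; within the scatter). For compound 3 the expected value is 2600 nM, with an estimated range from 1000 nM to 6500 nM.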

Compound 3, concentration for 50% growth inhibition: 1330 nM
Beside the measured number, compound 3's estimate is 2.0-fold (0.29 log units) above it; the measured number falls inside the stated range.
By their numbers in this assay, from the lowest: compounds 2 and 3 (each within the scatter of the next); then compound 1.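

In this assay, among the compounds shown here, methoxy in place of hydrogen on an aromatic carbon, meta to a fused ring and para to a fused ring, gives a 2.4-fold lower number from compound 1 to compound 3 (0.37 log units; beyond the scatter), which shows that a group at this place, empty in the earlier compounds, moves the number beyond the scatter towards stronger inhibition of growth. The step is modest, and so is the only earlier one, a 2.6-fold lower number from compound 1 to compound 2 (0.41 log units; beyond the scatter), which lies elsewhere in the structure, so both places respond to a single-group change with a lower number. Nothing at hand explains why methoxy at this place has this effect.

The compounds shown pair this place only with hydrogen and methoxy, so they leave open whether the lower number belongs to methoxy itself or would also follow from a chlorine atom, a hydroxyl or an amine there. They also leave open whether the step keeps its direction and size when the methoxy on the other aromatic ring is replaced by methyl, as it is in compound 2.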